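The compounds below may be only part of what the source reports. "The series", "measured", "known", "first", "only" and "open" are said of these compounds alone.

Three compounds built on a shared core were measured in an assay on isolated protein for inhibition of protein kinase C theta type (Homo sapiens), read by HTRF; on this read-out higher numbers stand for weaker inhibition and lower numbers for stronger inhibition. Compound 1 `CNC(=O)C[C@H]1O[C@@](C)(C(=O)OC)n2c3ccccc3c3c4c(c5c6ccccc6n1c5c32)C(=O)NC4` gives only a limit of the assay, > 2500 nM. Compound 2 `CO[C@@H]1[C@H](NC(=O)C(=O)c2c[nH]c3ccccc23)C[C@H]2O[C@]1(C)n1c3ccccc3c3c4c(c5c6ccccc6n2c5c31)C(=O)NC4` gives 1790 nM. Compound 3 `CO[C@H]1C(=O)C[C@H]2O[C@]1(C)n1c3ccccc3c3c4c(c5c6ccccc6n2c5c31)C(=O)NC4` gives 560 nM, the lowest of the two numbers, and its gap to compound 2 lies beyond the usual scatter. Compound 4 `CO[C@@H]1C(=O)C[C@H]2O[C@]1(C)n1c3ccccc3c3c4c(c5c6ccccc6n2c5c31)C(=O)NC4` has not yet been measured. It differs from compound 3 as follows: the two compounds have the same atoms and bonds and differ only in configuration as drawn: 1 of 3 stereo elements differ; a stereocentre at a saturated ring carbon is drawn R in compound 3 and S in compound 4. Among the measured compounds shown here, no measured pair here shows the effect of such a change, so the numbers back no direction. In this assay a step no larger than the scatter is expected, in either direction. Compound 4 is expected to give about 800 nM, within a range from 250 nM to 3000 nM. That expectation amounts to an estimated step of a 1.4-fold higher number from compound 3 to compound 4 (0.15 log units; within the scatter).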

Compound 4, half-maximal inhibitory concentration: > 2500 nM
Compound 4: a limit, no number; the forecaster's own chance of this, stated with the estimate: 15%; middle value at least 3.1-fold (0.49 log units) from the limit.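

In this assay, changing one stereocentre at a saturated ring carbon gives an at least 4.4-fold higher number from compound 3 to compound 4 (0.64 log units; beyond the scatter), the first single-place change seen here, and it shows that configuration at this carbon matters on the shared core. Compound 4 gives only a limit, so the true size of the step stays unknown: the limit of > 2500 nM in this assay, at which 2 of the 4 values shown sit. The comparison involves no other change: the fact that compounds 3 and 4 differ only in the configuration as drawn

On these data alone, it remains open how far compound 4 actually lies from compound 3. As far as these compounds go, it is also open whether the configuration of compound 3 stays favoured when a hydroxyl or an amine replaces the carbonyl.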